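A few compounds are considered here, and "the series" means these few. Any claim that something is new, unique, unknown or untested is made for them only; others in the source may bear on it.

Of the compounds shown here, three have so far been measured in a functional assay on MCF7 cells (Homo sapiens) for inhibition, read by resazurin assay, with a stated time of 72 h; a higher number here means a weaker inhibitor, a lower number a stronger inhibitor. Compound 1 `C=CC1C(=O)N(c2cc(OC)c(OC)c(OC)c2)C1c1ccc(OC)cc1` gives 17 nM. Compound 2 `COc1cc(N2C(=O)C(O)C2c2ccc(SC)cc2)cc(OC)c1OC` gives 5 nM, and compound 3 `CCOc1ccc(C2C(O)C(=O)N2c2cc(OC)c(OC)c(OC)c2)cc1` gives 7 nM. Going by the values given here, the only single-point step among them is a 1.4-fold higher number from compound 2 to compound 3 (0.15 log units; within the scatter), a change on the aromatic carbon. Compound 3 therefore stands second highest of the three numbers: compound 2 lies nearest, within the scatter, while compound 1 lies furthest, its number beyond the scatter above that of compound 3.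

Compound 4 `C=CC1C(=O)N(c2cc(OC)c(OC)c(OC)c2)C1c1ccc(OCC)cc1` has not yet been measured. It differs from compound 3 in one place: vinyl in place of hydroxy on a saturated ring carbon. Among the compounds with values here, no measured step touches this saturated ring carbon, so the step of a 1.4-fold higher number from compound 2 to compound 3 (0.15 log units; within the scatter) does not bear on it. Compound 1 also carries vinyl on a saturated ring carbon, but it differs from compound 3 in two places, so only its value can be set beside that of compound 3: compound 1 gives 17 nM, compound 3 gives 7 nM. On this slim footing a step of a 1.7-fold higher number from compound 3 to compound 4 (0.23 log units; within the scatter) is expected, toward a higher number, though it may not exceed the scatter. Compound 4 is estimated at 12 nM, within a range from 4 nM to 40 nM.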

Compound 4, half-maximal inhibitory concentration: 14 nM
Compound 4: middle estimate off by 1.2-fold (0.07 log units), on the low side, within the range that was stated.
By their numbers in this assay, from the lowest: compounds 2, 3, 4 and 1 (each within the scatter of the next, the first and the last beyond it).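

In this assay, going by these compounds alone, the step of a 2.0-fold higher number from compound 3 to compound 4 (0.30 log units; within the scatter) is the first measured step at this saturated ring carbon of the four-membered ring, and it lies within the scatter, though only just. Hydroxy and vinyl at this place therefore cannot be told apart in this assay, even though the exchange removes the hydrogen-bond donor and acceptor that hydroxy carries and adds a double bond outside the aromatic rings, so neither the donor nor the acceptor is shown to matter here. The step of a 1.2-fold lower number from compound 1 to compound 4 (0.08 log units; within the scatter), methyl in place of hydrogen on a saturated chain carbon bound to an oxygen on an aromatic ring, also lies within the scatter, which shows that with vinyl in place this change at the far aromatic ring cannot be told apart either, as was already so for the aromatic change between the two hydroxy compounds.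

As far as these compounds go, whether an amine, a carboxylic acid or a longer chain such as propyl at this saturated ring carbon would give a step beyond the scatter stays open, as does the outcome of vinyl paired with the methylsulfanyl group of compound 2. Nothing on hand explains the size of these steps, and no independent measurement bears on them.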